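Reversing the amine linker on a bile acid receptor agonist

The source may report more compounds than this note shows. Statements on the series, on what has been measured and on what is new or still open speak of the compounds shown alone.

Measured so far:
compound 1, `Cc1nc(OCc2c(-c3c(Cl)cccc3Cl)noc2C(C)C)ccc1N(C)C(=O)c1ccc(C(=O)O)cc1`, 2030 nM
compound 2, `CC(C)c1onc(-c2c(Cl)cccc2Cl)c1COc1ccc(N(C)Cc2cccc(C(=O)O)c2)c(C(F)(F)F)n1`, 80 nM
compound 3, `CN(Cc1cccc(C(=O)O)c1)c1ccc(OCc2c(-c3c(Cl)cccc3Cl)noc2C2CC2)nc1C(F)(F)F`, 9 nM

All three were tested in a functional assay on HEK293 cells for agonist activity at Bile acid receptor (Homo sapiens); on this read-out higher numbers stand for an effect only at larger amounts of compound and lower numbers for an effect already at smaller amounts. Compound 3 shows the lowest number of the three: compound 2 sits closest, and compound 1 furthest away. Within the data shown here, the only single-change step among them is an 8.9-fold lower number from compound 2 to compound 3 (0.95 log units; beyond the scatter); compound 1 differs from the others in several places at once, so its value can only be compared as a whole.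

Compound 4, `CC(Nc1ccc(C(=O)O)cc1)c1ccc(OCc2c(-c3c(Cl)cccc3Cl)noc2C2CC2)nc1C(F)(F)F`, has not yet been measured. It keeps every atom of compound 3 but joins them differently: 1-((4-carboxyphenyl)amino)ethyl in place of (3-carboxybenzyl)(methyl)amino on an aromatic carbon. The nitrogen that carried the methyl group and sat on the core is now a hydrogen-bond donor attached to the carboxyphenyl ring, and the acid has moved from the 3-position to the 4-position.

Among the measured compounds shown here, no measured step covers such a rearrangement. For the measured compounds named here, the only hint is that compound 1, which also carries a 4-carboxyphenyl on a nitrogen, gives a much higher number, but it differs in too many places to count as a guide. Compound 4 is therefore expected to give 40 nM, within 8 nM to 250 nM, a step of a 4.4-fold higher number from compound 3 to compound 4 (0.65 log units; beyond the scatter).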

Compound 4, half-maximal effective concentration: 333 nM
Estimate against measurement, compound 4: 8.3-fold (0.92 log units) below; the measured number lies above the stated range.
By their numbers in this assay, from the lowest: compound 3; then compound 2; then compound 4; then compound 1.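

In this assay, this place on the shared core proves highly sensitive to how the side chain is joined: a 37-fold higher number from compound 3 to compound 4 (1.57 log units; beyond the scatter). Among these compounds, earlier, the only single-change step concerned the group at the other end of the molecule, so this is the first direct reading of a change at the carbon ortho to the trifluoromethyl group, and it is a large one even though both groups hold the same 12 heavy atoms, including one six-membered aromatic ring of carbon only, and differ in their count of hydrogen-bond donors. No measurement here explains why this rearrangement gives such a large step.

The change alters several things at once, namely the link to the core, the nitrogen and the place of the carboxylic acid on the ring, so the compounds shown leave open which of these accounts for the step. A (4-carboxybenzyl)(methyl)amino group at this carbon would alter only the place of the acid relative to compound 3, and would begin to separate these effects.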